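Cyclopentylsulfanyl in Place of Cyclopentylamino: Cytotoxicity Outlook

This account rests on a few compounds, and the source may have more. Where it says the series, first, only, none or still open, it means among the compounds named here.

Compound 3 `Nc1nc(NC2CCCC2)c2ncn(/C=C3/CC3(CO)CO)c2n1` carries a cyclopentylamino group. In an ADME assay on CCRF-HSB-2 cells (Homo sapiens) for cytotoxicity, with a stated time of 7 days (on this read-out lower numbers stand for higher toxicity in this test and higher numbers for lower toxicity in this test), compound 3 gives only a limit, > 20000 nM. Compound 1 `CCOc1nc(N)nc2c1ncn2/C=C1/CC1(CO)CO` likewise reaches only a limit in this assay, > 20000 nM. Compound 2 `Nc1nc(N2CCCC2)c2ncn(/C=C3/CC3(CO)CO)c2n1` also stops at a limit in this assay, > 20000 nM. The steps a step that the two limits leave unreadable from compound 1 to compound 2, a step that the two limits leave unreadable from compound 1 to compound 3 and a step that the two limits leave unreadable from compound 2 to compound 3 are therefore unreadable, and the limit of > 20000 nM in this assay, at which 3 of the 3 values shown sit, shows every value resting on that limit. Compound 4 `Nc1nc(SC2CCCC2)c2ncn(/C=C3/CC3(CO)CO)c2n1` differs from compound 3 by cyclopentylsulfanyl in place of cyclopentylamino on an aromatic carbon. Among the compounds with values here, no measured step bears on this change in a readable way, so no direction can be drawn from them. With all three neighbours at the limit, compound 4 is expected to sit there as well, estimated at 25000 nM with a range from 10000 nM to 60000 nM, an expected step that the limit leaves unreadable from compound 3 to compound 4.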

Compound 4, half-maximal cytotoxic concentration: 91000 nM
Compound 4: middle estimate off by 3.6-fold (0.56 log units), on the low side, outside the stated range (above it).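

Within the data shown here, no step to compound 4 can be read from compound 1, compound 2 or compound 3, as each of those three rests on a limit: the limit of > 20000 nM in this assay, at which 3 of the 4 values shown sit. The compounds shown leave open how far compound 4 lies from any of them in this assay.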